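The source may report more compounds than this note shows. Statements on the series, on what has been measured and on what is new or still open speak of the compounds shown alone.

Of the compounds shown here, three built on a shared core have been tested in a functional assay on MGC-803 cells (Homo sapiens) for inhibition, read by MTT assay, with a stated time of 72 h; a lower number here means a stronger inhibitor, a higher number a weaker inhibitor. Compound 1 `Cc1cc(Nc2cc(-c3ccccc3)[nH]n2)n2nc(SCc3c(Cl)cccc3Cl)nc2n1` gives 5280 nM, the second highest of the three numbers. Compound 2 `Cc1cc(Nc2ccn(Cc3ccc(F)cc3)n2)n2nc(SCc3ccc(Br)cc3)nc2n1` gives 3070 nM and compound 3 `Cc1nc2nc(SCc3ccc(Cl)cc3)nn2c(Nc2cc(-c3ccccc3)[nH]n2)c1C` gives 9050 nM; each lies within the usual scatter of the number for compound 1, so no order among the three can be stated. Within the data shown here, no two of them differ in a single place, so no measured step exists yet. Compound 4 `Cc1cc(Nc2cc(-c3ccccc3)[nH]n2)n2ncnc2n1` differs from compound 1 in one place: hydrogen in place of (2,6-dichlorobenzyl)sulfanyl on an aromatic carbon. Among the measured compounds shown here, no measured compound lacks a group of this kind, so the change has no precedent among them. The step of a 2.8-fold higher number from compound 1 to compound 4 (0.45 log units; beyond the scatter) is expected to be a moderate weakening, beyond the scatter. Compound 4 is thus estimated at 15000 nM, between 5000 nM and 50000 nM.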

Compound 4, half-maximal inhibitory concentration: 21700 nM
For compound 4 the middle estimate is 1.4-fold (0.16 log units) below the measured one; the measured number falls inside the stated range.
By their numbers in this assay, from the lowest: compounds 2, 1 and 3 (each within the scatter of the next, the first and the last beyond it); then compound 4.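

Among these compounds, at the aromatic carbon between two ring nitrogen atoms, hydrogen in place of (2,6-dichlorobenzyl)sulfanyl gives in this assay a 4.1-fold higher number from compound 1 to compound 4 (0.61 log units; beyond the scatter) and so a modest weakening, the first step beyond the scatter that can be tied to one place. The group at this position thus matters to the number, although compound 4 without it still gives 21700 nM as a measured value. Nothing measured here explains the weakening.

The compounds shown leave open whether a smaller group at this carbon, such as methylsulfanyl or an amine, would keep the number of compound 1. They also leave open how much of the step belongs to the sulfur and how much to the dichlorinated ring.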